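A few compounds are considered here, and "the series" means these few. Any claim that something is new, unique, unknown or untested is made for them only; others in the source may bear on it.

Compound 1 `CC#C[C@H]1CN(S(=O)(=O)c2ccc(N)nc2)CCN1c1ccc([C@@](O)(CO)C(F)(F)F)cc1`: 53 mL.min-1.g-1
Compound 2 `CC#C[C@H]1CN(S(=O)(=O)c2ccc(N)nc2)CCN1c1ccc(S(=O)(=O)Nc2ccccc2)cc1`: > 399 mL.min-1.g-1 (a limit of the assay)
Compound 3 `CC#C[C@H]1CN(S(=O)(=O)c2ccc(N)nc2)CCN1c1ccc(S(=N)(=O)C2CC2)cc1`: 23 mL.min-1.g-1

In an ADME assay (liver) for metabolic stability, with Liver microsome (Rattus norvegicus) as the target, using microsomes and NADPH, with a stated time of 30 min (a lower number here means slower removal, a higher number faster removal of the compound), compound 3 gives 23 mL.min-1.g-1, the lower of the two true numbers. The nearest measured step is a 2.3-fold lower number from compound 1 to compound 3 (0.36 log units; beyond the scatter). Compound 2 gives > 399 mL.min-1.g-1, which is a limit and not a number.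

Compound 4 `CC#C[C@H]1CN(S(=O)(=O)c2ccc(N)nc2)CCN1c1ccc([S+](C)[O-])cc1` changes the group on the same aromatic carbon: a group of 3 heavy atoms (1 carbon, 1 oxygen, 1 sulfur; no ring) in place of a group of 6 heavy atoms (3 carbon, 1 nitrogen, 1 oxygen, 1 sulfur; one three-membered non-aromatic ring of carbon only), on an aromatic carbon. All three measured steps changed the group at this place. Two are wide, an at least 7.5-fold higher number from compound 1 to compound 2 (0.87 log units; beyond the scatter) and an at least 17-fold lower number from compound 2 to compound 3 (1.23 log units; beyond the scatter), but both involve compound 2 and its six-membered aromatic ring of carbon only, which compound 4 lacks. The better guide is therefore the modest step of a 2.3-fold lower number from compound 1 to compound 3 (0.36 log units; beyond the scatter), between two compounds without that ring. A small rise is expected, possibly no more than the scatter: a 1.3-fold higher number from compound 3 to compound 4 (0.12 log units; within the scatter). For compound 4 the estimated value is 30 mL.min-1.g-1, with an expected range of 12 mL.min-1.g-1 to 80 mL.min-1.g-1.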

Compound 4, intrinsic clearance in microsomes: 17 mL.min-1.g-1
The estimate for compound 4 lay 1.8-fold (0.25 log units) above the measured number; low and high end bracket the measured number.
By their numbers in this assay, from the lowest: compounds 4 and 3 (each within the scatter of the next); then compound 1. At a limit, above all of these: compound 2.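

In this assay, losing the three-membered ring and the hydrogen-bond donor from the group on this aromatic carbon moves the number only within the scatter: a 1.4-fold lower number from compound 3 to compound 4 (0.13 log units; within the scatter). The much smaller ring-free sulfur group of compound 4 therefore reads the same as the larger group of compound 3, and the step of a 3.1-fold lower number from compound 1 to compound 4 (0.49 log units; beyond the scatter) lies beyond the scatter, as the step from compound 1 to compound 3 does. The value of compound 2 is a limit of the assay, and the step of an at least 23-fold lower number from compound 2 to compound 4 (1.37 log units; beyond the scatter) rests on it: the limit of > 399 mL.min-1.g-1 in this assay, at which 1 of the 4 values shown sits.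

The compounds shown cannot say whether the six-membered aromatic ring of compound 2 or the rest of its group goes with its limit, and a sulfonamide without that ring would separate the two. Going by these compounds, how an amine or a carboxylic acid on this aromatic carbon would read also stays open.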